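Cytotoxicity Limits Across Three Close Analogues

The source may hold more compounds than are shown below. What is called first, only, known or untested is meant among the compounds shown, and "the series" means these compounds.

Compound 1, `C/C(=C\c1cc(-c2ccc(C#N)cc2)cs1)C(N)=O`, reaches only the limit > 50000 nM in an ADME assay on NIH3T3 cells (Mus musculus) for cytotoxicity, read by CCK-8 assay, with a stated time of 24 h; a lower number here means a stronger inhibitor, a higher number a weaker inhibitor.
Compound 2, `C/C(=C\c1cc(-c2ccc(S(C)(=O)=O)cc2)cs1)C(N)=O`, likewise reaches only the limit > 50000 nM in this assay.

Compound 2 therefore stands at a limit, not at a number, and the same is true of compound 1, as the limit of > 50000 nM in this assay, at which 2 of the 2 values shown sit, shows. The step that the two limits leave unreadable from compound 1 to compound 2 cannot be sized. Compound 3, `C/C(=C\c1cc(-c2ccc(Cl)cc2)cs1)C(N)=O`, carries chloro in place of methylsulfonyl on an aromatic carbon. Among the measured compounds shown here, the single measured step bears on it only in that both of its ends sit at the limit, so no shift beyond the scatter is expected. Compound 3 is estimated at 50000 nM, between 20000 nM and 100000 nM, an expected step of a number no higher from compound 2 to compound 3 (the limit leaves the size open).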

Compound 3, half-maximal inhibitory concentration: > 50000 nM
Compound 3 was reported as a limit; the forecaster's own chance of this, stated with the estimate: 80%; the middle value sits exactly at the limit.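

Among the compounds shown here, no step among compound 1, compound 2 and compound 3 can be read, since all three stand at one limit: the limit of > 50000 nM in this assay, at which 3 of the 3 values shown sit. The compounds shown leave open whether they differ at all in this assay.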